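A few compounds are considered here, and "the series" means these few. Any claim that something is new, unique, unknown or untested is made for them only; others in the source may bear on it.

Working notes on the series. Compound 2 `C[C@@H](c1ccc(Cl)cc1)N1Cc2cncn2C(CC2(C)COC2)S1(=O)=O` gives 7.8 nM in an assay on cells for inhibition of cytochrome P450 11B2, mitochondrial (Homo sapiens) (on this read-out higher numbers stand for weaker inhibition and lower numbers for stronger inhibition), the second highest of the three numbers measured; compound 3 `C[C@@H](c1ccc(Cl)cc1)N1Cc2cncn2C(C[C@@H](O)c2ccccc2)S1(=O)=O` gives 2.4 nM and compound 1 `CC(C)CC1n2cncc2CN(CC2CC2)S1(=O)=O` gives 758 nM. Compound 4 `CC(C)CC1n2cncc2CN([C@@H](C)c2ccc(Cl)cc2)S1(=O)=O` differs from compound 2 by isopropyl in place of 3-methyloxetan-3-yl on a saturated chain carbon bound to a saturated ring carbon. For the measured compounds named here, the only measured step at that place is a 3.3-fold lower number from compound 2 to compound 3 (0.51 log units; beyond the scatter), where an oxygen-bearing group replaced the oxetane and the number fell. Going by the values given here, compound 1 also carries isopropyl at this place and shows a high number, though its other substituent differs, so no step to it can be read. A modest rise is therefore expected, a 2.3-fold higher number from compound 2 to compound 4 (0.36 log units; beyond the scatter). Compound 4 is estimated at 18 nM, within 5 nM to 60 nM.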

Compound 4, half-maximal inhibitory concentration: 9.4 nM
Compound 4: middle estimate off by 1.9-fold (0.28 log units), on the high side, and the stated range covers the measured number.
By their numbers in this assay, from the lowest: compound 3; then compounds 2 and 4 (each within the scatter of the next); then compound 1.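

At the saturated chain carbon bound to a saturated ring carbon, isopropyl and 3-methyloxetan-3-yl are not told apart in this assay (a 1.2-fold higher number from compound 2 to compound 4 (0.08 log units; within the scatter)), so the ring and hydrogen-bond acceptor of 3-methyloxetan-3-yl are not required for a number of this size. Isopropyl and hydroxy(phenyl)methyl do separate (a 3.9-fold higher number from compound 3 to compound 4 (0.59 log units; beyond the scatter)), so the low number of compound 3 goes with hydroxy(phenyl)methyl and not with any oxygen-bearing group at this place. No evidence in hand accounts for these numbers. Going by these compounds, whether the hydroxyl or the phenyl of hydroxy(phenyl)methyl carries that step stays open, as does the outcome with a benzyl group or a primary amine here.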